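Ester and aryl variation in a small binding series

A few compounds are considered here, and "the series" means these few. Any claim that something is new, unique, unknown or untested is made for them only; others in the source may bear on it.

Measured compounds:
compound 1 `CCCOC(=O)C1=C(C)NC(=O)NC1c1ccoc1` — 11%
compound 2 `CC1=C(C(=O)OCC(C)C)C(c2ccoc2)NC(=O)N1` — 16%
compound 3 `CCCOC(=O)C1=C(C)NC(=O)NC1c1cccs1` — 32%

All three were run in an assay on membranes from HeLa cells for displacement of a labelled ligand from adenosine receptor A3 (Homo sapiens), read by scintillation counting, with a stated time of 180 min, tested at 1 uM; a lower number here means less inhibition, a higher number more inhibition at the concentration tested (going by the name of the read-out). Compound 1 gives 11%, compound 2 gives 16% and compound 3 gives 32% in this assay.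

Two single changes connect them. From compound 1 to compound 2 the change is methyl in place of hydrogen on a saturated chain carbon bound to two saturated chain carbons, and the step is a number 5 percentage points higher from compound 1 to compound 2 (within the scatter), so the two ester variants cannot be told apart on this read-out. From compound 1 to compound 3 the change is thiophen-2-yl in place of furan-3-yl on a saturated ring carbon, and here the step is a number 21 percentage points higher from compound 1 to compound 3 (beyond the scatter). Compound 3 thus stands highest of the three, with both other compounds beyond the scatter below it.

Compound 4 `CC1=C(C(=O)OCC(C)C)C(c2cccs2)NC(=O)N1` is not yet measured in this assay. Among the compounds with values here, it differs from compound 3 by methyl in place of hydrogen on a saturated chain carbon bound to two saturated chain carbons, the same change, at the same place, as the one from compound 1 to compound 2; the cores of the two pairs differ by thiophen-2-yl in place of furan-3-yl on a saturated ring carbon. The expected step from compound 3 to compound 4 is a number 5 percentage points higher from compound 3 to compound 4 (within the scatter), a small one, because the earlier instance of the change gave a number 5 percentage points higher from compound 1 to compound 2 (within the scatter). Compound 4 is therefore estimated at 37%, with a range from 22% to 52%.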

Compound 4, a percentage reported as inhibition, at one concentration (the size of the read-out at that concentration, not a potency): 11%
For compound 4 the middle estimate is 26 percentage points above the measured one; measured number outside the range, below it.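

In this assay, methyl in place of hydrogen on a saturated chain carbon bound to two saturated chain carbons, here propoxy to isobutoxy, gives a number 21 percentage points lower from compound 3 to compound 4 (beyond the scatter), so the step seen on the furan-3-yl core does not carry over to the thiophen-2-yl core: the same change on two cores in this assay, a number 5 percentage points higher (within the scatter) from compound 1 to compound 2 and a number 21 percentage points lower (beyond the scatter) from compound 3 to compound 4, 26 percentage points apart, beyond the scatter of two such steps

Read the other way, thiophen-2-yl in place of furan-3-yl gives a number 5 percentage points lower from compound 2 to compound 4 (within the scatter), so the rise seen with the propyl ester does not appear with the isobutyl ester: the same change on two cores in this assay, a number 21 percentage points higher (beyond the scatter) from compound 1 to compound 3 and a number 5 percentage points lower (within the scatter) from compound 2 to compound 4, 26 percentage points apart, beyond the scatter of two such steps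

The two changes therefore cannot be treated as independent in these four compounds, but the data do not show why, nor whether compound 3 is a lone exception or the start of a wider trend, and percentage inhibition at a single concentration gives no potency.

From the compounds shown here alone, whether an ethyl or butyl ester on the thiophen-2-yl core would read like compound 3 or like compound 4 remains open. Going by these compounds, it is also open whether a phenyl ring in place of the thiophen-2-yl group would show the same dependence on the ester.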